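Carboxy in Place of Cyano at the Assay Limit

A few compounds are considered here, and "the series" means these few. Any claim that something is new, unique, unknown or untested is made for them only; others in the source may bear on it.

Within the data shown here, only two compounds have been measured so far, and neither gives a number. In an ADME assay on cells (Fibroblast, Homo sapiens) for antiproliferative activity, with a stated time of 48 h (on this read-out higher numbers stand for weaker inhibition and lower numbers for stronger inhibition), compound 1 `COC(=O)c1cccc(-c2ccc(-n3cccc3)nn2)c1` gives > 25000 nM, which is a limit of the assay and not a number. Compound 2 `CCN(CC)c1ccc(-c2ccc(C#N)cc2)nn1` gives > 25000 nM, which is likewise a limit. From the compounds shown here alone, compound 2 thus stands at the limit of > 25000 nM in this assay, at which 2 of the 2 values shown sit, so its true position remains unknown.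

The next compound, compound 3 `CCN(CC)c1ccc(-c2ccc(C(=O)O)cc2)nn1`, keeps the shared core of compound 2 and changes one group. It carries carboxy in place of cyano on an aromatic carbon, para to a large group: carboxy in place of cyano on an aromatic carbon.

Among the measured compounds shown here, no measured step between two compounds bears on this change, and the only guide is the reading of compound 2 at > 25000 nM. In this assay, no shift beyond the scatter is therefore expected, and no direction can be named with confidence. The estimated step is a step that the limit leaves unreadable from compound 2 to compound 3. For compound 3 the expected value is 30000 nM, with an estimated range from 12000 nM to 70000 nM.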

Compound 3, half-maximal inhibitory concentration: > 25000 nM
Compound 3 gave a limit, no number; the forecaster's own chance of this, stated with the estimate: 85%; the middle value does not contradict the limit.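

In this assay compound 3 gives > 25000 nM, which is a limit of the assay and not a number. Compound 2 also stands at a limit, so no step can be read between compound 2 and compound 3. The compounds shown leave open whether carboxy in place of cyano changes the read-out at all, and where each compound truly stands: the limit of > 25000 nM in this assay, at which 3 of the 3 values shown sit.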